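The source may report more compounds than this note shows. Statements on the series, on what has been measured and on what is new or still open speak of the compounds shown alone.

Three compounds share one core and differ only in the amide group that sits on the carbonyl carbon. Compound 1 `CCN(CC)S(=O)(=O)c1ccc(S(=O)(=O)N2CCC[C@@H](C(=O)N3CCC(OC)CC3)C2)cc1` gives 1420 nM in a functional assay on BXPC-3 cells (Homo sapiens) for inhibition, read by MTT assay, with a stated time of 7 days; a lower number here means a stronger inhibitor, a higher number a weaker inhibitor. Compound 2 `CCN(CC)S(=O)(=O)c1ccc(S(=O)(=O)N2CCC[C@@H](C(=O)N3CCOCC3)C2)cc1` gives 790 nM in this assay, and compound 3 `CCN(CC)S(=O)(=O)c1ccc(S(=O)(=O)N2CCC[C@@H](C(=O)N3CCC(COC)CC3)C2)cc1` gives 1360 nM in this assay. Of these three numbers compound 3 holds the second highest, but the spread between them is small: a 1.0-fold lower number from compound 1 to compound 3 (0.02 log units; within the scatter), a 1.7-fold higher number from compound 2 to compound 3 (0.24 log units; within the scatter), and a 1.8-fold lower number from compound 1 to compound 2 (0.25 log units; within the scatter). Compound 4 `CCN(CC)S(=O)(=O)c1ccc(S(=O)(=O)N2CCC[C@@H](C(=O)N3CC[C@@H](OC)C3)C2)cc1` differs from compound 3 in that (3-methoxypyrrolidin-1-yl in place of 4-(methoxymethyl)piperidin-1-yl on a carbonyl carbon). Within the data shown here, no measured pair shows exactly this swap. The two steps that come closest, the exchange of the whole amide ring seen in a 1.7-fold higher number from compound 2 to compound 3 (0.24 log units; within the scatter) and the change of the ether group on that ring seen in a 1.0-fold lower number from compound 1 to compound 3 (0.02 log units; within the scatter), both stay within the scatter. The step to compound 4 is therefore expected to be none beyond the scatter, a 1.1-fold lower number from compound 3 to compound 4 (0.05 log units; within the scatter). Compound 4 is expected to give about 1200 nM in this assay, with a range from 500 nM to 3000 nM.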

Compound 4, half-maximal inhibitory concentration: 11500 nM
Compound 4: middle estimate off by 9.6-fold (0.98 log units), on the low side; the whole stated range lies below it.
By their numbers in this assay, from the lowest: compounds 2, 3 and 1 (each within the scatter of the next); then compound 4.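

At this carbonyl carbon, the amide group cannot be exchanged freely: the three earlier groups stayed within the scatter of one another, whereas 3-methoxypyrrolidin-1-yl gives a clear loss in this assay, with an 8.5-fold higher number from compound 3 to compound 4 (0.93 log units; beyond the scatter), an 8.1-fold higher number from compound 1 to compound 4 (0.91 log units; beyond the scatter) and a 15-fold higher number from compound 2 to compound 4 (1.16 log units; beyond the scatter). The step from 4-(methoxymethyl)piperidin-1-yl replaces a six-membered ring with a five-membered one, shortens the group and adds a defined stereocentre, so several features change at once. No available measurement explains the loss.

Going by these compounds, it remains open whether the five-membered ring alone accounts for the result, which plain pyrrolidin-1-yl, carrying no methoxy group, could help test. On these data alone, it is also open whether 3-methoxypyrrolidin-1-yl with the opposite arrangement at its stereocentre would behave the same way.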